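The compounds below may be only part of what the source reports. "The series", "measured", "known", "first", "only" and "open" are said of these compounds alone.

Compound 1, `O=C1N=C(N2CCC[C@H]2C(=O)Nc2ccc3ncnc(Nc4cccc(Cl)c4)c3c2)S/C1=C/c1cccs1`, is the reference point for this account. In a functional assay on A549 cells (Homo sapiens) for antiproliferative activity, read by MTT assay (a lower number here means a stronger inhibitor, a higher number a weaker inhibitor), compound 1 gives 6100 nM. Going by the values given here, of the two numbers in hand, compound 1 carries the higher one; its only neighbour is compound 2, `O=C1N=C(N2CCC[C@H]2C(=O)Nc2ccc3ncnc(Nc4cccc(Cl)c4)c3c2)S/C1=C/c1cccc(Br)n1`, which in this assay gives 3100 nM, and the step of a 2.0-fold lower number from compound 1 to compound 2 (0.29 log units; within the scatter) is within the scatter, so the two compounds cannot be told apart on these data.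

The compound not yet measured is compound 3, `O=C1N=C(N2CCC[C@H]2C(=O)Nc2ccc3ncnc(Nc4cccc(Cl)c4)c3c2)S/C1=C/c1ccccc1[N+](=O)[O-]`. It differs from compound 1 in one place: 2-nitrophenyl in place of thiophen-2-yl on a double-bonded chain carbon bound to a double-bonded ring carbon.

Among the compounds with values here, only one measured step touches this place, the exchange of thiophen-2-yl for 6-bromopyridin-2-yl on a double-bonded chain carbon bound to a double-bonded ring carbon, and it moved the number by a 2.0-fold lower number from compound 1 to compound 2 (0.29 log units; within the scatter), which is within the scatter. A single within-scatter step gives no ground for expecting a sizeable move in this assay in either direction when the same position carries 2-nitrophenyl instead.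

Compound 3 is therefore expected to give about 5000 nM in this assay, with a range from 1800 nM to 14000 nM. The expected step of a 1.2-fold lower number from compound 1 to compound 3 (0.09 log units; within the scatter) is thus no more than the scatter itself.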

Compound 3, half-maximal inhibitory concentration: > 50000 nM
Compound 3 ended at the assay's limit (the forecaster's own chance of this, stated with the estimate: 5%); middle value at least 10-fold (1.00 log units) from the limit.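

In this assay the result for compound 3 is a limit of the assay and not a number: the limit of > 50000 nM in this assay, at which 1 of the 3 values shown sits.

Even so, the place on a double-bonded chain carbon bound to a double-bonded ring carbon turns out not to be indifferent to what it carries: 2-nitrophenyl in place of thiophen-2-yl gives an at least 8.1-fold higher number from compound 1 to compound 3 (0.91 log units; beyond the scatter), and in place of 6-bromopyridin-2-yl it gives an at least 16-fold higher number from compound 2 to compound 3 (1.20 log units; beyond the scatter). Compound 1 and compound 2 alone could not show this, as they cannot be told apart, whereas compound 3 shows that a single exchange here can take the antiproliferative activity out of the range the assay reads, by an amount that has only a lower bound.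

The compounds shown do not separate the part played by the nitro group from that of the six-membered carbon ring, so it stays open whether an unsubstituted phenyl ring, or a phenyl ring carrying an amine or a methoxy group in place of the nitro group, would stay with compound 1 and compound 2 or fall away like compound 3. As far as these compounds go, how far compound 3 lies past its limit also remains unknown.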